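The source may hold more compounds than are shown below. What is called first, only, known or untested is meant among the compounds shown, and "the series" means these compounds.

In a physicochemical assay for pharmacokinetics, at pH 8 (a lower number here means that the compound disappears faster, a higher number that the compound lasts longer), compound 1 `COc1ccc(C(=O)Sc2cccnc2C(=O)O)cc1` gives 182 h and compound 2 `O=C(Sc1cccnc1C(=O)O)c1ccc(F)cc1` gives 111 h. Among the compounds with values here, these are the only two numbers so far, and the one measured step between them is a 1.6-fold lower number from compound 1 to compound 2 (0.21 log units; within the scatter). The two compounds therefore cannot be ranked, and compound 2 stands level with compound 1 within the usual scatter.

Compound 3 `O=C(Sc1cccnc1C(=O)O)c1ccc([N+](=O)[O-])cc1` keeps the shared core of compound 2 and carries nitro in place of fluoro on an aromatic carbon, para to a large group: nitro in place of fluoro on an aromatic carbon. Within the data shown here, this is the same aromatic carbon that changed in the measured step, so that step is the only guide available. Among the measured compounds shown here, it is a weak guide, as no nitro compound has been measured yet and the step stayed inside the scatter.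

Starting from compound 2 at 111 h, the expectation follows the direction of that step, but with a larger size. In this assay the expected step is a 3.2-fold lower number from compound 2 to compound 3 (0.50 log units; beyond the scatter), which would lie beyond the scatter. For compound 3 the estimated half-life is 35 h, with an expected range from 12 h to 90 h.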

Compound 3, half-life: 4.7 h
Estimate against measurement, compound 3: 7.4-fold (0.87 log units) above; measured number below the stated range.
By their numbers in this assay, from the lowest: compound 3; then compounds 2 and 1 (each within the scatter of the next).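

In this assay, the aromatic carbon para to a large group proves able to change the result strongly, which the earlier pair of compounds did not reveal. Nitro in place of fluoro gives a 24-fold lower number from compound 2 to compound 3 (1.37 log units; beyond the scatter), and nitro in place of methoxy gives a 39-fold lower number from compound 1 to compound 3 (1.59 log units; beyond the scatter). Fluoro and methoxy stand level with each other, so nitro is the group that separates from the others here, and compound 3 has the shortest half-life of the three compounds, with both of its steps lying beyond the usual scatter.

Nothing shown here bears on what lies behind this large drop in half-life. On these data alone, it also remains open whether other groups on this same carbon, such as an amine, a nitrile or a trifluoromethyl group, would stand level with compound 1 and compound 2, fall close to compound 3, or land somewhere between them, so three compounds cannot yet show a trend across groups at this position.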